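Swapping pyridine for pyrazine on a piperazine-bearing dithiocarbamate

This account rests on a few compounds, and the source may have more. Where it says the series, first, only, none or still open, it means among the compounds named here.

Compound 1, `Nc1ccccc1NC(=O)c1ccc(CSC(=S)N2CCN(c3ccncc3)CC2)cc1`, was tested in a functional assay on MGC-803 cells (Homo sapiens) for antiproliferative activity, read by CCK-8 assay, with a stated time of 72 h, tested at 2 uM; on this read-out lower numbers stand for a weaker effect and higher numbers for a stronger effect at the one concentration tested. At the single concentration used, compound 1 gives 64.8%. Its companion compound 2, `Nc1ccccc1NC(=O)c1ccc(CSC(=S)N2CCc3cc(Cl)ccc32)cc1`, gives 57.7% in the same test, so the two numbers lie within the usual scatter of each other and neither can be called the more active of the pair.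

Compound 3, `Nc1ccccc1NC(=O)c1ccc(CSC(=S)N2CCN(c3cnccn3)CC2)cc1`, differs from compound 1 in one place: pyrazin-2-yl in place of pyridin-4-yl on an amine nitrogen in a ring. Nothing else in the shared core changes. For the measured compounds named here, no measured pair of compounds shows what this kind of swap does, so there is no step to lean on. With both measured compounds sitting close together, the expected step from compound 1 to compound 3 is small, a number 4.8 percentage points lower from compound 1 to compound 3 (within the scatter), and not beyond the scatter in either direction. Compound 3 is therefore estimated at 60%, with a likely range from 45% to 75%.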

Compound 3, a percentage reported as inhibition, at one concentration (the size of the read-out at that concentration, not a potency): 27.1%
For compound 3 the middle estimate is 32.9 percentage points above the measured one, and the stated range ends above it.
By their numbers in this assay, from the lowest: compound 3; then compounds 2 and 1 (each within the scatter of the next).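

In this assay, this position proves sensitive to a seemingly modest change: pyrazin-2-yl in place of pyridin-4-yl gives a step of a number 37.7 percentage points lower from compound 1 to compound 3 (beyond the scatter). Both groups are six-membered aromatic rings with 6 heavy atoms on the same amine nitrogen, so even an exchange that leaves the heavy-atom count unchanged can markedly alter the effect at the one concentration tested. The compounds offer no measurement that explains the drop.

The swap changes both the number of ring nitrogens and where the ring is attached, and this single pair cannot separate the two. As far as these compounds go, a plain phenyl ring or a pyrimidine ring on the same amine nitrogen would help show which matters, and whether the drop seen with pyrazin-2-yl is specific to that group remains open.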